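The compounds below may be only part of what the source reports. "The series", "measured", "known", "first", "only" and "open" are said of these compounds alone.

Working notes on the sulfonamide series.

Compound 1 `Cc1ccccc1-n1cc(-c2ccc(NS(=O)(=O)c3c[nH]c(=O)[nH]c3=O)cc2)nn1` carries a 2-methylphenyl on the ring nitrogen; in a functional assay on SGC-7901 cells (Homo sapiens) for antiproliferative activity, read by MTT assay, with a stated time of 24 h (on this read-out higher numbers stand for weaker inhibition and lower numbers for stronger inhibition), compound 1 gives 13600 nM. Compound 2 `Cc1ccc(-n2cc(-c3ccc(NS(=O)(=O)c4c[nH]c(=O)[nH]c4=O)cc3)nn2)cc1` carries a 4-methylphenyl at the same position; in this assay compound 2 gives 8350 nM. Going by the values given here, the only measured step, a 1.6-fold lower number from compound 1 to compound 2 (0.21 log units; within the scatter), shows that moving the methyl around the phenyl ring changes nothing that can be separated from repeat scatter, and compound 2 therefore stands together with compound 1 rather than apart from it.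

Compound 3 `O=c1[nH]cc(S(=O)(=O)Nc2ccc(-c3cn(-c4ccccc4F)nn3)cc2)c(=O)[nH]1` is not yet measured. The change from compound 2 is 2-fluorophenyl in place of 4-methylphenyl on an aromatic nitrogen. Among the compounds with values here, the one measured step bears on it only loosely: it covers a methyl moved on the phenyl, not a fluorine, and it was within the scatter. Nothing in the two measured compounds speaks for a step beyond the scatter in either direction, so for this assay the expected step, a 1.3-fold higher number from compound 2 to compound 3 (0.12 log units; within the scatter), is close to none. Compound 3 is therefore estimated at 11000 nM, with a range from 4000 nM to 30000 nM, the width reflecting the lack of any fluorine-bearing comparator.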

Compound 3, half-maximal inhibitory concentration: 7270 nM
The estimate for compound 3 lay 1.5-fold (0.18 log units) above the measured number; the range from low to high includes it.
By their numbers in this assay, from the lowest: compounds 3, 2 and 1 (each within the scatter of the next).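

In this assay, going by these compounds alone, the first fluorine-bearing group at this position gives a 1.1-fold lower number from compound 2 to compound 3 (0.06 log units; within the scatter) and, with fluoro in place of methyl on an aromatic carbon, a 1.9-fold lower number from compound 1 to compound 3 (0.27 log units; within the scatter) as the second reading, both within the scatter. Within the data shown here, the earlier pair covered only a methyl moved around the phenyl, whereas compounds 1, 2 and 3 now show that 2-methylphenyl, 4-methylphenyl and 2-fluorophenyl on the aromatic nitrogen cannot be separated in this read-out, so exchanging methyl for fluoro adds no resolvable step in these compounds. No supporting measurement is available to explain this flat result.

On these data alone, all three compounds keep a singly substituted phenyl on the aromatic nitrogen, so it remains open whether an amine, a carboxylic acid or a longer alkyl chain on that phenyl, or a bare methyl in place of the whole phenyl, would give a step beyond the scatter. The shared core is also unchanged across compounds 1, 2 and 3, which leaves open how much of the antiproliferative reading depends on the sulfonamide linkage rather than on the group at this position.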